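Trimming the ether chain: from allyloxy to ethoxy

The compounds below may be only part of what the source reports. "The series", "measured", "known", "first", "only" and "open" are said of these compounds alone.

In a functional assay on RKO cells (Homo sapiens) for cytotoxicity, read by MTT assay, with a stated time of 48 h (a lower number here means a stronger inhibitor, a higher number a weaker inhibitor), compound 1 `CN(C)CCNc1ccnc2cc(OCc3ccc(F)cc3)ccc12` gives 580 nM, compound 2 `CCCCOc1ccc2c(Cl)ccnc2c1` gives 3050 nM, and compound 3 `C=CCOc1ccc2c(NCCN(C)C)ccnc2c1` gives 1270 nM. Compound 3 therefore stands second highest of the three numbers, above compound 1 and below compound 2. Compound 4 `CCOc1ccc2c(NCCN(C)C)ccnc2c1` differs from compound 3 at one place: methyl in place of vinyl on a saturated chain carbon bound to an oxygen on an aromatic ring. Going by the values given here, the only measured step at that same place is a 2.2-fold higher number from compound 1 to compound 3 (0.34 log units; beyond the scatter), in which vinyl replaced 4-fluorophenyl and the number rose modestly. Cutting the allyl chain down to ethyl is expected to bring a small further rise, or none beyond the scatter. Compound 4 is thus estimated at 1600 nM, within 700 nM to 3600 nM. The expected step is a 1.3-fold higher number from compound 3 to compound 4 (0.10 log units; within the scatter).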

Compound 4, half-maximal inhibitory concentration: 3650 nM
Compound 4: middle estimate off by 2.3-fold (0.36 log units), on the low side; measured number outside the range, above it.
By their numbers in this assay, from the lowest: compound 1; then compound 3; then compounds 2 and 4 (each within the scatter of the next).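

In this assay, the second trim at this place again raises the number: methyl in place of vinyl gives a further rise beyond the scatter (a 2.9-fold higher number from compound 3 to compound 4 (0.46 log units; beyond the scatter)). Over the three compounds with the dimethylaminoethylamino side chain, the number climbs as 4-fluorophenyl gives way to vinyl and then to methyl (a 6.3-fold higher number from compound 1 to compound 4 (0.80 log units; beyond the scatter)). Nothing measured here explains this order.

The compounds shown leave open whether a propoxy chain would fall on this order or away from it. They also leave open how a terminal amine on the ether chain would read.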